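The source may hold more compounds than are shown below. What is called first, only, known or untested is meant among the compounds shown, and "the series" means these compounds.

Compound 1 `CCN(CC)S(=O)(=O)c1ccc(S(=O)(=O)N2CCC[C@@H](C(=O)NC3CN(C(=O)OC(C)(C)C)C3)C2)cc1` — 1800 nM
Compound 2 `CCOC(=O)[C@@H]1CCCN(S(=N)(=O)c2ccc(S(=O)(=O)N(CC)CC)cc2)C1` — 13300 nM

Of the compounds shown here, two have been measured in a functional assay on BXPC-3 cells (Homo sapiens) for inhibition, read by MTT assay, with a stated time of 7 days; on this read-out lower numbers stand for stronger inhibition and higher numbers for weaker inhibition. Compound 1 gives 1800 nM, while compound 2 gives 13300 nM. Compound 1 therefore stands as the lower of the two numbers, and the gap to compound 2 lies beyond the usual scatter. The two structures differ in more than one place, so only what their two values show can be said of them.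

Compound 3 `CCN(CC)S(=O)(=O)c1ccc(S(=O)(=O)N2CCC[C@@H](C(=O)NC3CN(S(C)(=O)=O)C3)C2)cc1` has not yet been measured in this assay. It is built from compound 1 by a single change: methylsulfonyl in place of tert-butoxycarbonyl on an amine nitrogen in a ring. Read one bond further out, 1-(tert-butoxycarbonyl)azetidin-3-yl becomes 1-(methylsulfonyl)azetidin-3-yl. Among the measured compounds shown here, no measured pair shows this change, so the step of a 1.4-fold higher number from compound 1 to compound 3 (0.14 log units; within the scatter) is expected to be small, most likely within the scatter, with a slight lean toward a higher number. For compound 3 the estimate is 2500 nM, with a range from 800 nM to 8000 nM.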

Compound 3, half-maximal inhibitory concentration: 7400 nM
The estimate for compound 3 lay 3.0-fold (0.47 log units) below the measured number; low and high end bracket the measured number.
By their numbers in this assay, from the lowest: compound 1; then compounds 3 and 2 (each within the scatter of the next).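

In this assay, methylsulfonyl in place of tert-butoxycarbonyl on the amine nitrogen of the four-membered ring gives a 4.1-fold higher number from compound 1 to compound 3 (0.61 log units; beyond the scatter). Among the compounds shown here, this is the first step that can be read at a single place, and it shows that the number responds to the group on this nitrogen, with weaker inhibition after the change. Nothing measured here accounts for that step.

The compounds shown leave open whether an acetyl group, a free ring amine or a longer chain on the sulfonyl at this nitrogen would give a number nearer that of compound 1 or that of compound 3. They also leave open whether the same change would give a similar step on a core other than that of compound 1.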